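Pyridyl urea series: pyridine substituent swap on urea nitrogen

The compounds below may be only part of what the source reports. "The series", "measured", "known", "first", "only" and "open" are said of these compounds alone.

Three ureas have numbers in a functional assay on CHO cells for agonist activity at sphingosine 1-phosphate receptor 2 (Homo sapiens), read by fluorescence and calcium flux, with a stated time of 3 min; on this read-out lower numbers stand for stronger inhibition and higher numbers for weaker inhibition. Compound 1 `Cc1cc(CNC(=O)Nc2cc(Cl)cc(Cl)c2)ncc1-c1cn(C)nc1C` gives 3200 nM. Compound 2 `CCOc1cc(NC(=O)NCc2cc(C)c(-c3cn(C)nc3C(F)(F)F)nn2)cc(C#N)n1` gives 5500 nM, and compound 3 `CCOc1nc(C#N)cc(NC(=O)NCc2cc(C)c(-c3cn(C)nc3C(F)(F)F)nn2)c1C` gives 5500 nM. Compound 2 stands level with compound 3 at the digits shown, and its gap to compound 1 lies within the scatter, so the three measured compounds are not separated by this assay. Within the data shown here, the single one-place step, methyl in place of hydrogen on an aromatic carbon, gave no change at the digits printed from compound 2 to compound 3 (within the scatter).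

Compound 4 `CCOc1nc(C)cc(NC(=O)NCc2cc(C)c(-c3cn(C)nc3C(F)(F)F)nn2)c1Cl` is not yet measured. It differs from compound 2 by 3-chloro-2-ethoxy-6-methylpyridin-4-yl in place of 2-cyano-6-ethoxypyridin-4-yl on an amide-type nitrogen. Among the measured compounds shown here, no measured step tests the loss of the nitrile or the entry of chlorine and methyl on this ring; the only step that touches the same ring, from compound 2 to compound 3, was flat, and nothing among the measured compounds points in either direction. The expected outcome for compound 4 is therefore a step of no change at the digits printed from compound 2 to compound 4 (within the scatter), that is, none beyond the scatter. Compound 4 is estimated at 5500 nM in this assay, with a range from 1800 nM to 17000 nM.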

Compound 4, half-maximal inhibitory concentration: 4900 nM
The estimate for compound 4 lay 1.1-fold (0.05 log units) above the measured number, within the range that was stated.
By their numbers in this assay, from the lowest: compounds 1, 4, 2 and 3 (each within the scatter of the next).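

In this assay, the exchange of the whole group on the amide-type nitrogen gives a 1.1-fold lower number from compound 2 to compound 4 (0.05 log units; within the scatter), a wider change than the single methyl of the earlier step, since the nitrile leaves while chlorine and a ring methyl enter. Within this pair, the nitrile is thus not needed to keep the number at the level of compound 2, and the ethoxy group is the one substituent that both groups share. No measured data on this pair bear on why the read-out stays level.

The loss of the nitrile and the entry of chlorine and methyl arrive together, so their separate contributions, which could cancel, remain unresolved. Also open, as far as these compounds go, is whether an amine or a carboxylic acid in place of the nitrile, or a longer chain in place of ethoxy, would move the number beyond the scatter.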